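A few compounds are considered here, and "the series" means these few. Any claim that something is new, unique, unknown or untested is made for them only; others in the source may bear on it.

Measured so far in a functional assay on the whole organism for inhibition, with Mus musculus as the target, with stated times of 30 min and 2 h, at a dose of 10 mg/kg by the intraperitoneal route; a lower number here means less inhibition, a higher number more inhibition at the dose given (going by the name of the read-out):
compound 1, `Cc1ccc(S(=O)(=O)NCc2ccc(CNC(=O)c3ccc(F)cc3)cc2)cc1`: 75%
compound 2, `O=C(NCc1ccc(CNS(=O)(=O)c2ccccc2)cc1)c1cccnc1`: 53%
compound 3, `Cc1ccc(S(=O)(=O)NCc2ccc(CNC(=O)c3ccccc3Cl)cc2)cc1`: 26%

Compound 2 stands second highest of the three numbers in this assay: compound 1 lies above it beyond the scatter, compound 3 lies below it beyond the scatter. Neither pair shares a single-point difference with compound 2, so those two values are only read as they stand.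

Compound 4, `O=C(NCc1ccc(CNS(=O)(=O)c2ccccc2)cc1)c1ccncc1`, differs from compound 2 in one place: pyridin-4-yl in place of pyridin-3-yl on a carbonyl carbon. Going by the values given here, the only single-point step in the set is a number 49 percentage points lower from compound 1 to compound 3 (beyond the scatter). It sits on the same carbonyl carbon, but swaps one halogenated phenyl for another on a different core, and it involves no pyridine nitrogen at all, so it speaks only to how far a change at that position can move the read-out, not to the direction here. Among the compounds with values here, no measured pair addresses a shift of the ring nitrogen.

With that, no step beyond the scatter is firmly expected, and compound 4 is estimated at 45% (range 15% to 70%), an expected step of a number 8 percentage points lower from compound 2 to compound 4 (within the scatter).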

Compound 4, a percentage reported as inhibition, in the whole organism at one dose (the size of the read-out at that dose, not a potency): 40%
The estimate for compound 4 lay 5 percentage points above the measured number; measured number inside the range.
By their numbers in this assay, from the lowest: compound 3; then compound 4; then compound 2; then compound 1.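

In this assay the place of the ring nitrogen alone registers: with the same atoms and the same counted donors and acceptors, pyridin-4-yl in place of pyridin-3-yl on a carbonyl carbon gives a number 13 percentage points lower from compound 2 to compound 4 (beyond the scatter) in the read-out. Until now only a number 49 percentage points lower from compound 1 to compound 3 (beyond the scatter) spoke to this carbonyl carbon, and that step concerned halogenated phenyl groups on a different core; the new pair extends the sensitivity of this position to pyridine rings on the core of compound 2. No measurement at hand accounts for the difference.

Open, on these data alone, is whether the same order of the two pyridine groups holds on the core of compound 1. Also open, as far as these compounds go, is how pyridin-2-yl, unsubstituted phenyl or an aminomethyl-bearing phenyl on this carbonyl carbon would read on the core of compound 2.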